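The source may report more compounds than this note shows. Statements on the series, on what has been measured and on what is new or still open speak of the compounds shown alone.

Working notes on the series. In an assay for inhibition of Fatty-acid amide hydrolase 1 (Rattus norvegicus) (on this read-out higher numbers stand for weaker inhibition and lower numbers for stronger inhibition), compound 1 `O=C(O)c1ccc(-c2cnc(C(=O)CCc3ccc(-c4ccccc4)cc3)o2)cn1` gives 44 nM, the highest of the three numbers in hand. Compound 2 `CN(C)C(=O)c1cnc(C(=O)CCc2ccc(Oc3ccccc3)cc2)o1` gives 5.4 nM in this assay, and compound 3 `COC(=O)c1cnc(C(=O)CCc2ccc(COc3ccccc3)cc2)o1` gives 1.6 nM; both lie beyond the scatter from compound 1, compound 3 furthest off. Among the measured compounds shown here, none of these three differs from another in a single place, so no step is defined among them. Compound 4 `NC(=O)c1cccc(-c2cnc(C(=O)CCc3ccc(-c4ccccc4)cc3)o2)n1` is still unmeasured; it differs from compound 1 by 6-carbamoylpyridin-2-yl in place of 6-carboxypyridin-3-yl on an aromatic carbon. Given that compounds 2 and 3 sit well below compound 1, a step toward lower numbers, of moderate size, is expected, namely a 5.5-fold lower number from compound 1 to compound 4 (0.74 log units; beyond the scatter). Compound 4 is expected to give 8 nM in this assay, within 2 nM to 30 nM.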

Compound 4, inhibition constant: 1.2 nM
Beside the measured number, compound 4's estimate is 6.7-fold (0.82 log units) above it; the whole stated range lies above it.
By their numbers in this assay, from the lowest: compounds 4 and 3 (each within the scatter of the next); then compound 2; then compound 1.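

On the aromatic carbon next to the ring oxygen, 6-carbamoylpyridin-2-yl in place of 6-carboxypyridin-3-yl gives a 37-fold lower number from compound 1 to compound 4 (1.56 log units; beyond the scatter) in this assay. Among the compounds shown here, this is the first step read at this position, and it shows that the number here responds strongly to a change of substituent that keeps the heavy-atom count the same. Nothing at hand bears on the origin of this step.

The carboxy-to-carbamoyl swap and the shift in pyridine attachment travel together, so their shares remain unseparated. As far as these compounds go, whether 6-carboxypyridin-2-yl or 6-carbamoylpyridin-3-yl, or a nitrile in place of the carbamoyl group, would keep such a low number remains open.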